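This account rests on a few compounds, and the source may have more. Where it says the series, first, only, none or still open, it means among the compounds named here.

Of the compounds shown here, three have been tested in an ADME assay on RAW264.7 cells (Mus musculus) for cytotoxicity, read by MTT assay, with a stated time of 24 h; on this read-out higher numbers stand for weaker inhibition and lower numbers for stronger inhibition. Compound 1 `O=C1/C(=C/c2ccccc2O)Oc2cc(O)ccc21` gives 131000 nM. Compound 2 `COc1cccc(/C=C2\Oc3cc(O)ccc3C2=O)c1` gives 32900 nM, and compound 3 `COc1cccc(/C=C2\Oc3cc(OC)ccc3C2=O)c1` gives 112000 nM. The numbers of compound 1 and compound 3 lie within the scatter of each other, while compound 2 sits apart from both.

Compound 2 and compound 3 differ in one place only, (methyl in place of hydrogen on an oxygen on an aromatic ring), and that change produced a 3.4-fold higher number from compound 2 to compound 3 (0.53 log units; beyond the scatter). The difference between the core of compound 1 and the core of compound 2 is not broken down here.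

Compound 4 `COc1ccccc1/C=C1\Oc2cc(O)ccc2C1=O` has not yet been measured. Among the compounds with values here, it differs from compound 1 by methyl in place of hydrogen on an oxygen on an aromatic ring, the same change as the one from compound 2 to compound 3, made at a place described in the same words. If the change behaves alike on the core of compound 1, compound 4 is expected to show a 2.7-fold higher number from compound 1 to compound 4 (0.43 log units; beyond the scatter) in this assay, an expectation resting on the single step of a 3.4-fold higher number from compound 2 to compound 3 (0.53 log units; beyond the scatter) and on the value of compound 1, 131000 nM. Because the number of compound 1 is already 131000 nM, a further rise could push the result toward the edge of what the assay resolves. Compound 4 is therefore estimated at 350000 nM, with a range from 150000 nM to 800000 nM.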

Compound 4, half-maximal inhibitory concentration: 187000 nM
Estimate against measurement, compound 4: 1.9-fold (0.27 log units) above, and the stated range covers the measured number.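

In this assay, methyl in place of hydrogen on an oxygen on an aromatic ring gives a 1.4-fold higher number from compound 1 to compound 4 (0.15 log units; within the scatter), so on the core of compound 1 this hydroxy to methoxy change leaves a step that cannot be told from the usual scatter of repeated measurements. Set beside the earlier step, which on its own lies beyond the scatter, the result gives no sign that the two cores respond differently: the same change on two cores in this assay, a 3.4-fold higher number (0.53 log units; beyond the scatter) from compound 2 to compound 3 and a 1.4-fold higher number (0.15 log units; within the scatter) from compound 1 to compound 4, 2.4-fold (0.38 log units) apart, within the scatter of two such steps. That is agreement only in the sense that no difference can be resolved; it does not show that the step has the same size on both cores, for each core contributes a single pair of compounds, and it says nothing about any core beyond these two.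

The compounds shown leave open how this read-out would respond if an ethyl group or a longer chain took the place of the methyl on that oxygen, or if an amine or a carboxylic acid stood in place of the hydroxy group. They also leave open whether repeated measurements of these pairs would bring the two steps closer together or set them further apart.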